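Dropping a Methylsulfanyl Group: Expected Effect on Growth Inhibition

A few compounds are considered here, and "the series" means these few. Any claim that something is new, unique, unknown or untested is made for them only; others in the source may bear on it.

Compound 1, `CSc1ccc(CNc2nc(SC)nc3ncccc23)cc1`, was tested in a functional assay on HTB-54 cells (Homo sapiens) for cytotoxicity, read by MTT assay, with a stated time of 72 h (a lower number here means a stronger inhibitor of growth, a higher number a weaker inhibitor of growth), where compound 1 gives 14800 nM. Compound 2, `CSc1nc(NCCCCc2ccccc2)c2ccccc2n1`, in this assay reaches only (the limit of > 100000 nM in this assay, at which 1 of the 2 values shown sits), so its entry of > 100000 nM is a limit rather than a number. Among the measured compounds shown here, compound 1 thus holds the only real value shown. Compound 3, `CSc1nc(NCc2ccccc2)c2cccnc2n1`, differs from compound 1 by hydrogen in place of methylsulfanyl on an aromatic carbon. For the measured compounds named here, no measured pair of this kind exists here. Compound 3 is expected to give 22000 nM, between 6000 nM and 80000 nM. The step of a 1.5-fold higher number from compound 1 to compound 3 (0.17 log units; within the scatter) is expected to stay modest, a slight loss at most.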

Compound 3, concentration for total growth inhibition: 51600 nM
Estimate against measurement, compound 3: 2.3-fold (0.37 log units) below; measured number inside the range.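

In this assay, among the compounds shown here, replacing the methylsulfanyl group with hydrogen, para to a large group, gives a 3.5-fold higher number from compound 1 to compound 3 (0.54 log units; beyond the scatter) in the first measured step at this position. The step is modest, but it shows that the group at this place counts for growth inhibition, and that hydrogen there gives the weaker inhibitor of the pair. Nothing shown here accounts for the size of this step.

Going by these compounds, only hydrogen stands against methylsulfanyl at this place, so it remains open whether the sulfur atom itself matters. A methoxy group, a chlorine atom or an amine there could help to settle this.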